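Swapping one link in the side chain of compound 1

The source may hold more compounds than are shown below. What is called first, only, known or untested is meant among the compounds shown, and "the series" means these compounds.

Measured so far in an ADME assay on Vero cells (Chlorocebus sabaeus) for cytotoxicity, read by reporter gene assay, with a stated time of 4 days; on this read-out higher numbers stand for weaker inhibition and lower numbers for stronger inhibition
compound 1 `CCCC(C)C(=O)NCC(C)(C)CC1=C(O)C(=O)c2ccccc2C1=O` gives 48100 nM
compound 2 `CCCCCCCC(=O)NCC(C)(C)CC1=C(O)C(=O)c2ccccc2C1=O` gives 18400 nM
compound 3 `CCCCCCCCCCC(=O)NCC(C)(C)CC1=C(O)C(=O)c2ccccc2C1=O` gives 14900 nM

Compound 1 holds the highest number of the three. Compound 4 `CCCC(C)C(=O)OCC(C)(C)CC1=C(O)C(=O)c2ccccc2C1=O` keeps the core of compound 1 and changes one thing (((1-methylbutyl)carbonyl)oxy in place of ((1-methylbutyl)carbonyl)amino on a saturated chain carbon, three bonds along the chain from a double-bonded ring carbon), with ((1-methylbutyl)carbonyl)oxy in place of ((1-methylbutyl)carbonyl)amino. Going by the values given here, no measured step makes this swap, so the data give no direct guide to it. The nearest evidence comes from changes to the chain on the carbonyl carbon. Two of those steps are modest (a 2.6-fold lower number from compound 1 to compound 2 (0.42 log units; beyond the scatter)) and (a 3.2-fold lower number from compound 1 to compound 3 (0.51 log units; beyond the scatter)), while a third stays within the scatter (a 1.2-fold lower number from compound 2 to compound 3 (0.09 log units; within the scatter)). These show only how far a different edit moved the number in this small set. Since compound 1 already sits at the top (48100 nM), any shift seems likelier to go lower. In this assay the expected step is small and within the scatter (a 1.4-fold lower number from compound 1 to compound 4 (0.14 log units; within the scatter)), though the uncertainty is wide. For compound 4 the estimate is (35000 nM), with an expected range from (14000 nM) to (80000 nM).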

Compound 4, half-maximal inhibitory concentration: 120 nM
Compound 4: the middle estimate sits 290-fold (2.46 log units) above what was measured; the whole stated range lies above it.
By their numbers in this assay, from the lowest: compound 4; then compounds 3 and 2 (each within the scatter of the next); then compound 1.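

In this assay, the step of a 400-fold lower number from compound 1 to compound 4 (2.60 log units; beyond the scatter) shows that this link, on a saturated chain carbon, three bonds along the chain from a double-bonded ring carbon, can move the number far more than the chain on the carbonyl carbon did, where the largest change was a 3.2-fold lower number from compound 1 to compound 3 (0.51 log units; beyond the scatter). Exchanging ((1-methylbutyl)carbonyl)amino for ((1-methylbutyl)carbonyl)oxy keeps the heavy-atom count and replaces nitrogen with oxygen, leaving 0 hydrogen-bond donors in the group, so a single-atom change can turn a weakly inhibiting compound into a strongly inhibiting one here. Nothing available explains the size of this drop.

Still open, on these data alone, is whether the same swap has a similar effect with the heptyl and decyl chains. It is also unclear where a ketone link or an amide nitrogen bearing a methyl group would fall.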